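From (sec-butyl)amino to 4-methylpiperazin-1-yl on a carbonyl carbon

A few compounds are considered here, and "the series" means these few. Any claim that something is new, unique, unknown or untested is made for them only; others in the source may bear on it.

Compounds measured in a functional assay on the whole organism with Mus musculus as the target; on this read-out lower numbers stand for an effect already at smaller amounts and higher numbers for an effect only at larger amounts of compound:
Compound 1 `CNC(=O)/C(C)=C/c1cccc(C(F)(F)F)c1`: 75 mg/kg
Compound 2 `O=C1CCC(O)(c2cccc(C(F)(F)F)c2)N1`: > 200 mg/kg (a limit, not a number)
Compound 3 `CCC(C)NC(=O)CCC(=O)c1cccc(C(F)(F)F)c1`: > 200 mg/kg (a limit, not a number)

Among the measured compounds shown here, only one compound in this small set has a true number, and that is compound 1 at 75 mg/kg. Compound 3 stands on (the limit of > 200 mg/kg in this assay, at which 2 of the 3 values shown sit). Its position is therefore known only as a limit, and the true value of compound 3 is not known.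

The next compound, compound 4 `CN1CCN(C(=O)CCC(=O)c2cccc(C(F)(F)F)c2)CC1`, carries 4-methylpiperazin-1-yl in place of (sec-butyl)amino on a carbonyl carbon. For the measured compounds named here, no measured pair of compounds in the set differs in one place only, so nothing shows directly how large such a change tends to be in this assay. With no such guide, no step beyond the usual scatter is expected, in either direction. The expectation rests on compound 3, whose limit is > 200 mg/kg. The estimated change is a number no higher from compound 3 to compound 4 (the limit leaves the size open). It is also expected that the assay may again report only a limit. Compound 4 is estimated at 200 mg/kg, with an expected range from 80 mg/kg to 400 mg/kg.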

Compound 4, dose for half-maximal effect: > 50 mg/kg
Compound 4 ended at the assay's limit (the forecaster's own chance of this, stated with the estimate: 60%); the middle value lies beyond the limit too.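

In this assay compound 4 gives > 50 mg/kg, a limit and not a number. Compound 3 gives > 200 mg/kg, likewise a limit, so no step can be read between compound 3 and compound 4. The compounds shown leave open whether 4-methylpiperazin-1-yl in place of (sec-butyl)amino on a carbonyl carbon shifts the read-out at all, in either direction.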